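A Long Sulfanyl Chain Replaces Benzyloxy

The source may hold more compounds than are shown below. What is called first, only, known or untested is meant among the compounds shown, and "the series" means these compounds.

Compounds measured in an ADME assay on HFF cells (Homo sapiens) for cytotoxicity, with a stated time of 8 days; a higher number here means that more compound is tolerated, a lower number that less compound is tolerated:
compound 1 `CNc1nc(N)nc2c1ncn2/C=C1/CC1(CO)CO`: 265000 nM
compound 2 `COCCOc1nc(N)nc2c1ncn2/C=C1/CC1(CO)CO`: > 300000 nM, a limit
compound 3 `Nc1nc(OCc2ccccc2)c2ncn(/C=C3/CC3(CO)CO)c2n1`: > 300000 nM, a limit

Compound 3 gives no number in this assay, only the limit > 300000 nM. It therefore stands at the limit of > 300000 nM in this assay, at which 2 of the 3 values shown sit.

The next compound, compound 4 `CCCCCCCCSc1nc(N)nc2c1ncn2/C=C1/CC1(CO)CO`, differs from compound 3 by octylsulfanyl in place of benzyloxy on an aromatic carbon.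

Two measured changes on this same aromatic carbon bear most directly on the question. They gave an at least 1.1-fold higher number from compound 1 to compound 2 (0.05 log units; that floor lies within the scatter), and an at least 1.1-fold higher number from compound 1 to compound 3 (0.05 log units; that floor lies within the scatter). The comparison of the two limit compounds gives a step that the two limits leave unreadable from compound 2 to compound 3. Going by the values given here, none of these steps shows a change beyond the scatter, but the limits conceal their true sizes, and no measured compound carries octylsulfanyl.

As far as these compounds go, no step beyond the scatter is therefore expected in this assay, although the range must stay open on the lower side. Among the compounds with values here, the only numeric reference is compound 1 at 265000 nM. The expected change is an at least 1.5-fold lower number from compound 3 to compound 4 (0.17 log units; that floor lies within the scatter). The estimated half-maximal cytotoxic concentration for compound 4 is 200000 nM, with an expected range of 60000 nM to 300000 nM.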

Compound 4, half-maximal cytotoxic concentration: > 300000 nM
Compound 4: a limit, no number (the forecaster's own chance of this, stated with the estimate: 40%); middle value at least 1.5-fold (0.17 log units) from the limit.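

In this assay compound 4 gives > 300000 nM as a limit and not a number. Octylsulfanyl, the only sulfanyl chain among the compounds shown, thus joins 2-methoxyethoxy and benzyloxy on this aromatic carbon, and three different groups there now end at the same limit: (the limit of > 300000 nM in this assay, at which 3 of the 4 values shown sit) The one step that can be read (an at least 1.1-fold higher number from compound 1 to compound 4 (0.05 log units; that floor lies within the scatter)) gives only a floor, while the steps to compound 4 from compound 2 and compound 3 cannot be read, with limits at both of their ends.

As far as these compounds go, how far compound 2, compound 3 and compound 4 lie from one another remains open, as does the question of whether any group on this carbon gives a number clearly lower than that of compound 1. An octylamino chain would pair the length of octylsulfanyl with the amino link of methylamino in compound 1, and a carboxylic acid at the end of the chain would test whether the limit still holds.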